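The compounds below may be only part of what the source reports. "The series", "measured", "known", "first", "only" and "open" are said of these compounds alone.

Working notes on the cytotoxicity series.

Four compounds of one shared core are in view: compound 1 `CC(C)(C)CCN1C(=O)C(C2=NS(=O)(=O)c3cc(NS(C)(=O)=O)ccc3N2)=C(O)C2CCCCCCC21`, compound 2 `CS(=O)(=O)Nc1ccc2c(c1)S(=O)(=O)N=C(C1=C(O)C3CCCC3N(CCC3CC3)C1=O)N2`, compound 3 `CS(=O)(=O)Nc1ccc2c(c1)S(=O)(=O)N=C(C1=C(O)[C@H]3CCC[C@H]3N(Cc3ccc(F)c(F)c3)C1=O)N2` and the as yet unmeasured compound 4 `CC(C)CCN1C(=O)C(C2=NS(=O)(=O)c3cc(NS(C)(=O)=O)ccc3N2)=C(O)C2CCCC21`. In an ADME assay on Huh-7 cells (Homo sapiens) for cytotoxicity, with a stated time of 72 h (a lower number here means that less compound is tolerated, a higher number that more compound is tolerated), compound 1 gives "not determined" (no result reported). In this assay compound 2 gives only a limit of the assay, > 33000 nM. In this assay compound 3 likewise gives only a limit, > 1000 nM. Where compound 2 stands is thus known only as the limit of > 33000 nM in this assay, at which 1 of the 3 values shown sits, while compound 3 sits at the limit of > 1000 nM in this assay, at which 1 of the 3 values shown sits, and compound 1 has no number; no step between measured compounds can be read from these entries.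

The change from compound 2 to compound 4 is isopropyl in place of cyclopropyl on a saturated chain carbon, two bonds along the chain from an amide-type nitrogen in a ring. Nothing measured in the series speaks to the size or direction of such a step in this assay; the expectation is a step of a number no higher from compound 2 to compound 4 (the limit leaves the size open), that is, none beyond the scatter. Compound 4 is therefore estimated at 33000 nM in this assay, within a range of 15000 nM to 80000 nM, and most probably again reported only as a limit.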

Compound 4, half-maximal cytotoxic concentration: > 1000 nM
Compound 4: no number, only a limit; the forecaster's own chance of this, stated with the estimate: 70%; the middle value lies beyond the limit too.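

In this assay, compound 2 and compound 4 are each reported only as a limit of the assay, so no step can be read between them. The compounds shown leave open what concentration of either compound is actually tolerated, and whether isopropyl in place of cyclopropyl changes the read-out at all.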